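Hydroxy Added to the Isopropyl of a Triazole Urea

The source may hold more compounds than are shown below. What is called first, only, known or untested is meant among the compounds shown, and "the series" means these compounds.

Compound 1 `CC(C)n1cnnc1-c1cccc(NC(=O)Nc2ccc3ccccc3n2)n1` gives 2340 nM in an assay on isolated protein for inhibition of mitogen-activated protein kinase kinase kinase 6 (Homo sapiens) (a higher number here means a weaker inhibitor, a lower number a stronger inhibitor), the higher of the two numbers recorded so far. Compound 2 `C[C@H](CO)n1cnnc1-c1cccc(NC(=O)Nc2nccc3ccccc23)n1` differs from compound 1 in several places. In this assay compound 2 gives 264 nM, and the gap between the two lies beyond the scatter. Compound 3 `C[C@H](CO)n1cnnc1-c1cccc(NC(=O)Nc2ccc3ccccc3n2)n1` carries a single change from compound 1: hydroxy in place of hydrogen on a saturated chain carbon, two bonds along the chain from an aromatic nitrogen. Within the data shown here, no step with this change alone has been recorded, so the expectation rests on the two values shown: a move to a lower number is expected, of about a 2.6-fold lower number from compound 1 to compound 3 (0.41 log units; beyond the scatter). Compound 3 is therefore estimated at 900 nM, with a range of 300 nM to 2500 nM.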

Compound 3, half-maximal inhibitory concentration: 2860 nM
Estimate against measurement, compound 3: 3.2-fold (0.50 log units) below, outside the stated range (above it).
By their numbers in this assay, from the lowest: compound 2; then compounds 1 and 3 (each within the scatter of the next).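

In this assay, the change from isopropyl to 1-(hydroxymethyl)ethyl gives a 1.2-fold higher number from compound 1 to compound 3 (0.09 log units; within the scatter) and so, on the core of compound 1, adding the hydroxy group at this position leaves the number within the scatter. The lower number of compound 2 at 264 nM is thus not matched by compound 3 at 2860 nM despite the shared 1-(hydroxymethyl)ethyl group. Nothing available explains this result. Still open, on these data alone, is whether an amine or a carboxylic acid in place of the hydroxy group, or a longer chain, would shift the number at this position. Also open, as far as these compounds go, is whether the same hydroxy change would matter on the core of compound 2.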